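The compounds below may be only part of what the source reports. "The series", "measured", "known", "first", "only" and "open" are said of these compounds alone.

Measured compounds:
- compound 1 `N#Cc1ccc(S(=O)(=O)N2C/C(=C\c3cccnc3)C(=O)/C(=C/c3ccccc3F)C2)cc1` — > 20000 nM (a limit of the assay, not a number)
- compound 2 `Cc1ccc(S(=O)(=O)N2C/C(=C\c3cccnc3)C(=O)/C(=C/c3ccccc3C(F)(F)F)C2)cc1` — 12300 nM

Among the measured compounds shown here, in an ADME assay on L02 cells (Homo sapiens) for cytotoxicity, read by MTT assay, with a stated time of 24 h (on this read-out lower numbers stand for stronger inhibition and higher numbers for weaker inhibition), compound 2 gives 12300 nM, the only number in this set. Compound 1 sits at a limit of this assay, > 20000 nM, and no number is known for it (the limit of > 20000 nM in this assay, at which 1 of the 2 values shown sits). For the measured compounds named here, compound 1 and compound 2 differ in two places, so the two values show only that one is a number and the other a limit.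

Compound 3 `N#Cc1ccc(S(=O)(=O)N2C/C(=C\c3cccnc3)C(=O)/C(=C/c3ccccc3C(F)(F)F)C2)cc1` has not yet been measured. It differs from compound 2 in one place: cyano in place of methyl on an aromatic carbon. Going by the values given here, no step between measured compounds isolates this change, so the direction of the step is unknown. The values shown include a limit (the limit of > 20000 nM in this assay, at which 1 of the 2 values shown sits), and compound 1 carries the same cyano group that enters here, so a small shift toward higher numbers, not clearly beyond the scatter, is expected from compound 2 to compound 3 a 1.5-fold higher number from compound 2 to compound 3 (0.17 log units; within the scatter). Compound 3 is therefore estimated at 18000 nM, within 9000 nM to 40000 nM, with a fair chance that this assay reports only a limit.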

Compound 3, half-maximal inhibitory concentration: 13200 nM
Compound 3: middle estimate off by 1.4-fold (0.13 log units), on the high side; the range from low to high includes it.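

In this assay, the change from (4-methylphenyl)sulfonyl to (4-cyanophenyl)sulfonyl now stands alone, with the trifluoromethyl group held constant, and it gives a 1.1-fold higher number from compound 2 to compound 3 (0.03 log units; within the scatter), so on this background the read-out does not separate methyl from cyano at this position. The second comparison holds the cyano group constant and puts trifluoromethyl in place of fluoro on an aromatic carbon, giving an at least 1.5-fold lower number from compound 1 to compound 3 (0.18 log units; that floor lies within the scatter), and this step offers only a floor, one that does not show a separation. Compound 1 carries a limit of the assay and not a number, so the real size of that step stays unknown: the limit of > 20000 nM in this assay, at which 1 of the 3 values shown sits.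

The compounds shown leave open whether cyano and methyl would also read alike with fluoro in place of trifluoromethyl, as only one such pair can be compared. They also leave open whether a different group at this position, such as an amine or a carboxylic acid, would give a number in this assay that stands clear of the scatter.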